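Carbonyl substituent variation in a potassium channel binding series

A few compounds are considered here, and "the series" means these few. Any claim that something is new, unique, unknown or untested is made for them only; others in the source may bear on it.

Compound 1 `CCCC(C)C(=O)Nc1c(C(O)(C(F)(F)F)C(F)(F)F)ccc2ccccc12`: in an assay on LtK cells with ATP-sensitive inward rectifier potassium channel 11 (Homo sapiens) as the target (on this read-out higher numbers stand for an effect only at larger amounts of compound and lower numbers for an effect already at smaller amounts), compound 1 gives only a limit, > 10000 nM.
Compound 2 `O=C(Nc1c(C(O)(C(F)(F)F)C(F)(F)F)ccc2ccccc12)C1CCCC1`: in this assay compound 2 gives 495 nM.
Compound 3 `CC(C)OC(=O)Nc1c(C(O)(C(F)(F)F)C(F)(F)F)ccc2ccccc12`: in this assay compound 3 gives 1160 nM.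

Among the measured compounds shown here, compound 3 carries the higher of the two numbers measured so far; its nearest neighbour is compound 2, and the step of a 2.3-fold higher number from compound 2 to compound 3 (0.37 log units; beyond the scatter) separates them. Compound 1 sits at the limit of > 10000 nM in this assay, at which 1 of the 3 values shown sits, and contributes no number.

Compound 4 `COc1cccc(C(=O)Nc2c(C(O)(C(F)(F)F)C(F)(F)F)ccc3ccccc23)c1` has not yet been measured. Relative to compound 3 the change is 3-methoxyphenyl in place of isopropoxy on a carbonyl carbon. Both measured steps that exchange the group on the carbonyl carbon bear on it: an at least 8.6-fold lower number from compound 1 to compound 3 (0.93 log units; beyond the scatter) and a 2.3-fold higher number from compound 2 to compound 3 (0.37 log units; beyond the scatter). Among the three groups tried on that carbon, the ring cyclopentyl gave the lowest number, isopropoxy a somewhat higher one, and the open chain 1-methylbutyl only a limit. 3-Methoxyphenyl brings a ring of a kind not yet tried on this carbonyl carbon, so the number of compound 4 is expected to land near that of compound 2, with wide uncertainty. In this assay compound 4 is expected at 600 nM, between 150 nM and 3000 nM. This expectation means a 1.9-fold lower number from compound 3 to compound 4 (0.29 log units; within the scatter).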

Compound 4, half-maximal effective concentration: 185 nM
The estimate for compound 4 lay 3.2-fold (0.51 log units) above the measured number, within the range that was stated.
By their numbers in this assay, from the lowest: compound 4; then compound 2; then compound 3. At a limit, above all of these: compound 1.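

The carbonyl carbon accepts a six-membered aromatic ring, and in this assay 3-methoxyphenyl gives a lower number than isopropoxy (a 6.3-fold lower number from compound 3 to compound 4 (0.80 log units; beyond the scatter)) and than cyclopentyl (a 2.7-fold lower number from compound 2 to compound 4 (0.43 log units; beyond the scatter)). Cyclopentyl had held the lowest number at this carbon, so a low number here is not confined to a saturated ring, and the order now runs from compound 4 through compound 2 to compound 3. The widest gap is to 1-methylbutyl (an at least 54-fold lower number from compound 1 to compound 4 (1.73 log units; beyond the scatter)), but that step starts from compound 1, whose entry is a limit and not a number: the limit of > 10000 nM in this assay, at which 1 of the 4 values shown sits.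

With only one aromatic group shown, the contribution of the ring cannot be separated from that of its methoxy group, and an unsubstituted phenyl would be the direct comparison. As far as these compounds go, how a pyridyl ring, or a phenyl ring carrying a carboxylic acid or an amine in place of the methoxy group, would read in this assay also remains open.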